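This account rests on a few compounds, and the source may have more. Where it says the series, first, only, none or still open, it means among the compounds named here.

Compound 3, `CC(C)N(c1cc(C#CC(C)(C)C)sc1C(=O)O)C(=O)[C@H]1CC[C@H](Cl)CC1`, sits at the top of the three measured numbers in an ADME assay for protein binding, using equilibrium dialysis, at pH 7.4, tested at 2 uM; a higher number here means a larger unbound share of the compound, a lower number a smaller unbound share: compound 3 gives 0.14. Compound 1, `CON=C1CCC(N(c2cc(C#CC(C)(C)C)sc2C(=O)O)C(=O)[C@H]2CC[C@H](C)CC2)CC1`, gives 0.07 in this assay, and compound 2, `C[C@@H](CCOc1cccnc1)N(c1cc(C#CC(C)(C)C)sc1C(=O)O)C(=O)[C@H]1CC[C@H](C)CC1`, gives 0.02. The gap from compound 3 to compound 1 lies within the scatter, while the gap from compound 3 to compound 2 lies beyond it. Going by the values given here, the one measured step, a 3.5-fold lower number from compound 1 to compound 2 (0.54 log units; beyond the scatter), concerns a change on the amide-type nitrogen and therefore does not bear directly on the change now considered.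

Compound 4, `CC(C)N(C(=O)[C@@H]1CC[C@@H]2C[C@@H]2CC1)c1cc(C#CC(C)(C)C)sc1C(=O)O`, differs from compound 3 on the carbonyl carbon: a group of 8 heavy atoms (8 carbon; one three-membered non-aromatic ring of carbon only, one seven-membered non-aromatic ring of carbon only) in place of a group of 7 heavy atoms (6 carbon, 1 chlorine; one six-membered non-aromatic ring of carbon only), on a carbonyl carbon. Among the compounds with values here, no measured pair alters this part of the shared core, so the direction of the step is open. The expected step from compound 3 to compound 4 in this assay is a 1.4-fold lower number from compound 3 to compound 4 (0.15 log units; within the scatter), that is, no movement clearly beyond the scatter. Compound 4 is accordingly estimated to give 0.1 in this assay, within a range of 0.04 to 0.25.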

Compound 4, unbound fraction: 0.05
Compound 4: the middle estimate sits 2.0-fold (0.30 log units) above what was measured; the range from low to high includes it.
By their numbers in this assay, from the lowest: compound 2; then compounds 4, 1 and 3 (each within the scatter of the next, the first and the last beyond it).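

Going by these compounds alone, exchanging the 4-chlorocyclohexyl group on the carbonyl carbon for the group with a three-membered and a seven-membered ring gives, in this assay, a 2.8-fold lower number from compound 3 to compound 4 (0.45 log units; beyond the scatter), the only measured step at this position. The group on the carbonyl carbon, and not only the group on the amide-type nitrogen, can therefore shift this read-out beyond the scatter, and this exchange shifts it downward. Nothing at hand explains the step or separates the loss of the chlorine from the change of ring system.

Going by these compounds, how a plain cyclohexyl group, or a cyclohexyl group carrying a hydroxyl or an amine, would read on this carbonyl carbon remains open. On these data alone, it is also open whether the step would hold with the groups of compound 1 or compound 2 on the amide-type nitrogen.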